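A 3-Chlorophenyl Group on the Carbonyl Carbon

The source may hold more compounds than are shown below. What is called first, only, known or untested is meant among the compounds shown, and "the series" means these compounds.

Of the compounds shown here, two sharing one core have been measured in a functional assay on B16-F10 cells (Mus musculus) for antiproliferative activity, read by MTT assay, with a stated time of 48 h; on this read-out higher numbers stand for weaker inhibition and lower numbers for stronger inhibition. In this test, compound 1 `COc1ccc(/C=C/c2cc(OC)cc(OC)c2/C=C/C(=O)c2cccc(OC)c2)cc1` gives 4.3 ug/mL. Compound 2 `CCCCOc1ccc(C(=O)/C=C/c2c(/C=C/c3ccc(OC)cc3)cc(OC)cc2OC)cc1` gives 5.3 ug/mL. These two numbers lie within the scatter of each other, so compound 2 stands together with compound 1 and no order can be read between them.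

Compound 3 `COc1ccc(/C=C/c2cc(OC)cc(OC)c2/C=C/C(=O)c2cccc(Cl)c2)cc1`, not yet measured, keeps the core of compound 2 but carries 3-chlorophenyl in place of 4-butoxyphenyl on a carbonyl carbon. Among the compounds with values here, only one measured step bears on this place. It is a 1.2-fold higher number from compound 1 to compound 2 (0.09 log units; within the scatter), with 4-butoxyphenyl in place of 3-methoxyphenyl on a carbonyl carbon. Within the data shown here, that single step stayed within the scatter, but no compound with a chlorine-bearing group has been measured, so the evidence is thin. No step beyond the scatter is therefore expected in this assay, in either direction. The expected change is a 1.2-fold lower number from compound 2 to compound 3 (0.07 log units; within the scatter). For compound 3 the estimated value is 4.5 ug/mL, with an expected range from 2 ug/mL to 10 ug/mL.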

Compound 3, half-maximal inhibitory concentration: 3.3 ug/mL
Beside the measured number, compound 3's estimate is 1.4-fold (0.13 log units) above it; measured number inside the range.
By their numbers in this assay, from the lowest: compounds 3, 1 and 2 (each within the scatter of the next).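

In this assay, within the data shown here, the group on the carbonyl carbon now includes a chlorine-bearing ring for the first time, and the exchange of 4-butoxyphenyl for 3-chlorophenyl gives a 1.6-fold lower number from compound 2 to compound 3 (0.21 log units; within the scatter) while the exchange of methoxy for chloro on an aromatic carbon gives a 1.3-fold lower number from compound 1 to compound 3 (0.11 log units; within the scatter) and so neither step separates the compounds. The earlier pair had shown only two oxygen-bearing aromatic groups at this place, whereas compound 3 shows that a ring with no hydrogen-bond acceptor and no butoxy chain also stands together with them, so that 3-methoxyphenyl, 4-butoxyphenyl and 3-chlorophenyl cannot be told apart here. Nothing shown gives a reason for this lack of separation at the carbonyl carbon.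

Still open, from the compounds shown here alone, is whether any group at this place would produce a step beyond the scatter, for instance a ring carrying a carboxylic acid, a ring carrying a dimethylamino group, or a ring with bromine in place of chlorine. Also open, going by these compounds, is whether a longer chain than butoxy, or an open-chain group with no aromatic ring at all, would stand with these three compounds.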